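Swapping a nitrile for a chlorophenyl thioether in two cores

This account rests on a few compounds, and the source may have more. Where it says the series, first, only, none or still open, it means among the compounds named here.

Compound 1 `Cc1cc(C#N)cn2c(CSCCc3ccccc3)cnc12` gives 14 ug/mL in an ADME assay on HEL cells (Homo sapiens) for cytotoxicity, with a stated time of 3 days; on this read-out lower numbers stand for higher toxicity in this test and higher numbers for lower toxicity in this test. Compound 2 `Cc1cc(Sc2ccc(Cl)cc2)cn2c(CSCCc3ccccc3)cnc12` gives 14 ug/mL in this assay. Compound 1 to compound 2 is (4-chlorophenyl)sulfanyl in place of cyano on an aromatic carbon, and the result was no change at the digits printed from compound 1 to compound 2 (within the scatter). Compound 3 `Cc1cc(C#N)c2ncc(CSCCc3ccccc3)n2c1` has a different core from compound 1; the difference between the two cores is not broken down here. In this assay compound 3 gives only a limit, > 100 ug/mL, which is the limit of > 100 ug/mL in this assay, at which 1 of the 3 values shown sits. Compound 4 `Cc1cc(Sc2ccc(Cl)cc2)c2ncc(CSCCc3ccccc3)n2c1` carries (4-chlorophenyl)sulfanyl in place of cyano on an aromatic carbon; this is the same kind of change, though here the place is ortho to a fused ring rather than para to a fused ring. Compound 3 to compound 4 is expected to be a number no higher from compound 3 to compound 4 (the limit leaves the size open) because no change at the digits printed from compound 1 to compound 2 (within the scatter) was flat. Compound 4 is thus estimated at 100 ug/mL, between 30 ug/mL and 300 ug/mL.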

Compound 4, half-maximal cytotoxic concentration: 100 ug/mL
For compound 4 middle estimate and measured number coincide at the digits printed; measured number inside the range.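

Compound 3 gives > 100 ug/mL in this assay, which is a limit of the assay and not a number, so the size of the step to compound 4 cannot be read. Putting (4-chlorophenyl)sulfanyl in place of cyano gives a number no higher from compound 3 to compound 4 (the limit leaves the size open). Set side by side, the two cores give this picture for the same change: the same change on two cores in this assay, no change at the digits printed (within the scatter) from compound 1 to compound 2 and a number no higher (the limit leaves the size open) from compound 3 to compound 4; the limit leaves it open whether they differ. The second pair therefore neither confirms nor rules out that the swap of nitrile for (4-chlorophenyl)sulfanyl carries over from one core to the other, and two pairs would not establish a rule for the series in any case.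

The compounds shown leave open how an amine or a carboxylic acid at this place would read. They also leave open what a longer chain in place of the methyl group would do.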